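This account rests on a few compounds, and the source may have more. Where it says the series, first, only, none or still open, it means among the compounds named here.

Measured so far:
- compound 1, `Nc1cccc(-c2cnc3[nH]cc(-c4ccncc4)c3c2)c1`, 42.7 nM
- compound 2, `Nc1cncc(-c2cnc3[nH]cc(-c4ccncc4)c3c2)c1`, 69.6 nM
- compound 3, `Cc1ccc(-c2cnc3[nH]cc(-c4ccncc4)c3c2)cc1N`, 22.2 nM

The three compounds share one core and differ only in the ring that carries the amino group. In an assay on isolated protein for inhibition of high affinity nerve growth factor receptor (Homo sapiens), read by 33P incorporation (on this read-out lower numbers stand for stronger inhibition and higher numbers for weaker inhibition), compound 1 gives 42.7 nM, the second highest of the three numbers. Exchanging its ring for a 5-aminopyridin-3-yl gives a 1.6-fold higher number from compound 1 to compound 2 (0.21 log units; within the scatter), and adding a methyl to that ring gives a 1.9-fold lower number from compound 1 to compound 3 (0.28 log units; within the scatter); both steps stay within the scatter, so the three compounds cannot be ranked against each other.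

Compound 4, `CC(=O)Nc1cccc(-c2cnc3[nH]cc(-c4ccncc4)c3c2)c1`, is built from compound 1 by a change at the amino group itself: acetyl in place of hydrogen on a nitrogen on an aromatic ring, that is, amino to acetamido. Neither measured step touches this nitrogen, so neither bears directly on the change; they only show that small changes on this ring have so far moved the number little. Among the measured compounds shown here, with no direct precedent, the expectation for compound 4 is a modest weakening, a 2.1-fold higher number from compound 1 to compound 4 (0.32 log units; beyond the scatter), with wide uncertainty. Compound 4 is therefore estimated at 90 nM, within a range of 25 nM to 320 nM.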

Compound 4, half-maximal inhibitory concentration: 34.3 nM
For compound 4 the middle estimate is 2.6-fold (0.42 log units) above the measured one; low and high end bracket the measured number.
By their numbers in this assay, from the lowest: compounds 3, 4, 1 and 2 (each within the scatter of the next, the first and the last beyond it).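

Among the compounds shown here, the earlier steps changed the ring but left the amino nitrogen untouched, so this is the first look at a change on that nitrogen itself. In this assay, putting acetyl, a group of 3 heavy atoms, in place of hydrogen on this nitrogen gives a 1.2-fold lower number from compound 1 to compound 4 (0.10 log units; within the scatter) and leaves the two compounds indistinguishable. For this one pair, then, the amino group can be turned into an acetamido group without a readable loss, though nothing measured here explains this result.

On these data alone, whether a longer acyl chain such as hexanoyl, or a methanesulfonyl group, on this nitrogen would keep the number in the same range remains open. Also open, as far as these compounds go, is whether the same acetyl would give a similar step on the aminopyridine ring of compound 2 or the methyl-bearing ring of compound 3.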